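The source may hold more compounds than are shown below. What is called first, only, known or untested is meant among the compounds shown, and "the series" means these compounds.

Working notes on the series. Compound 1, `Cn1cnc(CS(=O)(=O)c2ccc(Cl)cc2)c1[N+](=O)[O-]`, and compound 2, `Cn1cnc(CS(=O)(=O)c2ccc(Br)cc2)c1[N+](=O)[O-]`, share one core; compound 3, `Cc1nc(CS(=O)(=O)c2ccc(Cl)cc2)c([N+](=O)[O-])n1CCO`, and compound 4, `Cc1nc(CS(=O)(=O)c2ccc(Br)cc2)c([N+](=O)[O-])n1CCO`, share another. The difference between the two cores is not broken down here. In an ADME assay on THP-1 cells (Homo sapiens) for cytotoxicity, read by flow cytometry and propidium iodide staining, with a stated time of 72 h (on this read-out higher numbers stand for weaker inhibition and lower numbers for stronger inhibition), compound 1 gives 174000 nM. Compound 2 gives > 694000 nM in this assay, which is a limit rather than a number. That reading stands at the limit of > 694000 nM in this assay, at which 1 of the 3 values shown sits. The change from compound 1 to compound 2 is bromo in place of chloro on an aromatic carbon, and it brings an at least 3.9-fold higher number from compound 1 to compound 2 (0.60 log units; beyond the scatter). Compound 3 gives 578000 nM in this assay. Compound 4 is not yet measured in this assay; it differs from compound 3 by bromo in place of chloro on an aromatic carbon, the same kind of change, sitting on an aromatic carbon of a six-membered aromatic ring of carbon only, para to a large group, and cut one bond further out it reads 4-chlorophenyl to 4-bromophenyl. Compound 4 is expected to give 1500000 nM in this assay, estimated between 500000 nM and 5000000 nM. The expected step is a 2.6-fold higher number from compound 3 to compound 4 (0.41 log units; beyond the scatter), a higher number, which rests on an at least 3.9-fold higher number from compound 1 to compound 2 (0.60 log units; beyond the scatter). Going by the values given here, compound 3 already gives 578000 nM in this assay, the higher of the two numbers measured so far.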

Compound 4, half-maximal inhibitory concentration: 124000 nM
Compound 4: the middle estimate sits 12-fold (1.08 log units) above what was measured; the measured number lies below the stated range.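

In this assay, bromo in place of chloro on an aromatic carbon gives a 4.7-fold lower number from compound 3 to compound 4 (0.67 log units; beyond the scatter), so the direction of the step on the core of compound 1 does not carry over to the core of compound 3: the same change on two cores in this assay, an at least 3.9-fold higher number (0.60 log units; beyond the scatter) from compound 1 to compound 2 and a 4.7-fold lower number (0.67 log units; beyond the scatter) from compound 3 to compound 4, at least 18-fold (1.26 log units) apart, beyond the scatter of two such steps

Compound 2 gives > 694000 nM, which is a limit and not a number.

The two pairs show that, in this series, the outcome of this change depends on the core it sits on, but they do not show which part of the difference between the cores goes with the reversal, nor do they give a rule for any further core.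

The compounds shown leave open whether fluoro or a nitrile on the same aromatic carbon would follow the trend of either core. They also leave open whether the reversal would persist with an amine or a carboxylic acid at the end of the chain on the core of compound 3.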